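This account rests on a few compounds, and the source may have more. Where it says the series, first, only, none or still open, it means among the compounds named here.

Measured compounds:
compound 1, `CC1CCN(C2CCN(S(=O)(=O)c3ccc(-c4ccccc4F)cc3)CC2)CC1`, 5 nM;
compound 2, `Cc1cc(C)c(S(=O)(=O)NC2CCN(C3CCN(C)CC3)CC2)c(C)c1`, 958 nM.

The account concerns two compounds measured in a functional assay on DLD-1 cells (Homo sapiens) for antiproliferative activity, read by CellTiter-Glo, with a stated time of 72 h; a higher number here means a weaker inhibitor, a lower number a stronger inhibitor. Compound 1 `CC1CCN(C2CCN(S(=O)(=O)c3ccc(-c4ccccc4F)cc3)CC2)CC1` gives 5 nM, the lowest number of the two, and compound 2 `Cc1cc(C)c(S(=O)(=O)NC2CCN(C3CCN(C)CC3)CC2)c(C)c1`, which gives 958 nM, sits far above it, a gap well beyond the usual scatter. For the measured compounds named here, no pair of measured compounds differs in a single place, so no step between them is known.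

The piece follows the change from compound 1 to compound 3 `COC(=O)c1ccc(S(=O)(=O)N2CCC(N3CCC(C)CC3)CC2)cc1`, which has not yet been measured in this assay. The change is methoxycarbonyl in place of 2-fluorophenyl on an aromatic carbon. Going by the values given here, the only other measured compound, compound 2, carries a single aromatic ring in this region and gives the much higher number, but it differs from compound 1 in several other places, so its value tells nothing firm about this change.

Compound 3 is therefore expected to give a higher number than compound 1, a step of a 20-fold higher number from compound 1 to compound 3 (1.30 log units; beyond the scatter), beyond the scatter but short of the gap to compound 2. For compound 3 the estimate is 100 nM, within a range from 15 nM to 800 nM.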

Compound 3, half-maximal inhibitory concentration: > 5000 nM
Compound 3 gave a limit, no number; the forecaster's own chance of this, stated with the estimate: 5%; middle value at least 50-fold (1.69 log units) from the limit.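

In this assay compound 3 gives > 5000 nM, which is a limit of the assay and not a number, so the reading ends there and the full size of the change stays unknown: the limit of > 5000 nM in this assay, at which 1 of the 3 values shown sits.

Even so, methoxycarbonyl in place of 2-fluorophenyl, on an aromatic carbon para to a large group, gives an at least 1000-fold higher number from compound 1 to compound 3 (3.00 log units; beyond the scatter), and this is the first step known between two compounds that differ in one place only. For the compounds shown here, it shows what the earlier compounds could not: with the rest of compound 1 unchanged, the group at this position alone can carry the number from the low nanomolar region up to the limit of the assay, so the activity of compound 1 does not survive every replacement here.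

The compounds shown do not separate the loss of the aromatic ring from the entry of the hydrogen-bond acceptors of methoxycarbonyl, nor do they show what the fluorine of 2-fluorophenyl contributes. From the compounds shown here alone, a plain phenyl, a pyridine ring, a nitrile or a carboxylic acid at this place remains open, so how much of the step belongs to each part of the change cannot be read from these values.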